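Working notes: step from compound 2 to compound 4

A few compounds are considered here, and "the series" means these few. Any claim that something is new, unique, unknown or untested is made for them only; others in the source may bear on it.

Measured so far in a functional assay on HCT-116 cells (Homo sapiens) for cytotoxicity, read by resazurin assay, with a stated time of 48 h (on this read-out lower numbers stand for an effect already at smaller amounts and higher numbers for an effect only at larger amounts of compound), as follows
- compound 1 `O=S(=O)(Nc1ccc(-c2nc3cc(NS(=O)(=O)c4ccccc4)ccc3o2)cc1)c1ccccc1` gives 13000 nM 
- compound 2 `COc1ccc(S(=O)(=O)Nc2ccc(-c3nc4cc(NS(=O)(=O)c5ccc(OC)cc5)ccc4o3)cc2)cc1` gives 12000 nM 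
- compound 3 `O=S(=O)(Nc1ccc(-c2nc3cc(NS(=O)(=O)c4ccccc4Cl)ccc3o2)cc1)c1ccccc1Cl` gives 12000 nM 

Compound 2 stands level with compound 3, and compound 1 lies within the scatter of both, so the three values do not separate. Compound 4 `COc1ccc(S(=O)(=O)Nc2ccc3oc(-c4ccc(NC(=O)c5cccc(C)c5[N+](=O)[O-])cc4)nc3c2)cc1` differs from compound 2 in one place: (3-methyl-2-nitrophenyl)carbonyl in place of (4-methoxyphenyl)sulfonyl on a nitrogen on an aromatic ring, with (3-methyl-2-nitrophenyl)carbonyl in place of (4-methoxyphenyl)sulfonyl on a nitrogen on an aromatic ring. Within the data shown here, no measured pair shows the size of a single change, so the expectation rests only on compound 2 (12000 nM) and the flat values around it. In this assay no step beyond the scatter is expected, in either direction. The expected 1.2-fold lower number from compound 2 to compound 4 (0.08 log units; within the scatter) is therefore small. The estimate for compound 4 is 10000 nM with an expected range of 3000 nM to 30000 nM as its limits.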

Compound 4, half-maximal effective concentration: 4400 nM
For compound 4 the middle estimate is 2.3-fold (0.36 log units) above the measured one; the measured number falls inside the stated range.
By their numbers in this assay, from the lowest: compound 4; then compounds 2, 3 and 1 (each within the scatter of the next).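

In this assay, the nitrogen on an aromatic ring tolerates a change that shifts the read-out: (3-methyl-2-nitrophenyl)carbonyl in place of (4-methoxyphenyl)sulfonyl gives a 2.7-fold lower number from compound 2 to compound 4 (0.44 log units; beyond the scatter), whereas compound 1, compound 2 and compound 3 stay within the scatter of one another. The step is modest and rests on this single pair. Nothing available bears on its cause.

The change swaps the sulfonyl for a carbonyl and alters the ring substituents together, so the compounds shown do not separate these contributions. Also open, from the compounds shown here alone, is how a plain benzoyl or an acetyl group on this nitrogen would read.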